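A few compounds are considered here, and "the series" means these few. Any claim that something is new, unique, unknown or untested is made for them only; others in the source may bear on it.

Measured compounds:
- compound 1 `O=C(CN1CCN(c2ccccn2)CC1)Nc1cccnc1`: 86500 nM
- compound 2 `Cc1ccc(C2CCN(CC(=O)Nc3cccc(C)c3)CC2)nc1`: 453 nM

In a functional assay on cells for antagonist activity at D(4) dopamine receptor (Homo sapiens), read by TR-FRET and cAMP accumulation, with a stated time of 30 min (a lower number here means a stronger inhibitor, a higher number a weaker inhibitor), compound 1 gives 86500 nM, the higher of the two numbers on hand, so it is the weaker inhibitor of the pair. Compound 2, with 453 nM in this assay, sits far lower, a gap well beyond the usual scatter, but the two structures differ in several places at once, so no single change can be read from that pair.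

Compound 3 `O=C(CN1CCN(c2ccc(Cl)cn2)CC1)Nc1cccnc1` has not yet been measured. It keeps the whole of compound 1 except for one change: chloro in place of hydrogen on an aromatic carbon, on the six-membered aromatic ring with one nitrogen, two atoms from the ring nitrogen and para to a large group; put more broadly, the pyridin-2-yl group becomes a 5-chloropyridin-2-yl group.

Going by the values given here, with no measured pair showing this exact change, the size of the step is uncertain. A small addition of this kind is expected to lower the number by a moderate amount, beyond the scatter, as a 4.3-fold lower number from compound 1 to compound 3 (0.64 log units; beyond the scatter). Compound 3 is therefore estimated at 20000 nM in this assay, with a plausible range from 5000 nM to 80000 nM.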

Compound 3, half-maximal inhibitory concentration: 40000 nM
The estimate for compound 3 lay 2.0-fold (0.30 log units) below the measured number; measured number inside the range.
By their numbers in this assay, from the lowest: compound 2; then compound 3; then compound 1.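

In this assay, going by these compounds alone, the change from pyridin-2-yl to 5-chloropyridin-2-yl gives a 2.2-fold lower number from compound 1 to compound 3 (0.33 log units; beyond the scatter), the first comparison here in which only one place differs. It shows that a single chlorine atom on this ring, two atoms from the ring nitrogen and para to a large group, shifts the number by a modest step that lies beyond the usual scatter, so this position does affect the read-out, though compound 3 still stands at 40000 nM. The data on hand offer no explanation for the size or direction of this step.

Going by these compounds, with one substituent at one position, it remains open whether a methoxy group, a nitrile or an amine in place of the chloro would lower the number further, leave it unchanged or raise it. On these data alone, it is also open whether chloro at another carbon of this ring, or the same change on the core of compound 2, would give a step of similar size.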